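A few compounds are considered here, and "the series" means these few. Any claim that something is new, unique, unknown or untested is made for them only; others in the source may bear on it.

Values in an in vitro functional assay on cells for agonist activity at Bombesin receptor subtype-3 (Homo sapiens), read by luminescence and calcium flux; a higher number here means that more compound is needed for the effect, a lower number that less compound is needed:
compound 1, `O=C(O)c1ccccc1-c1ccc(CCc2ncc(CC3CCC3)[nH]2)cc1`: 588 nM
compound 2, `O=C(O)c1ccccc1-c1ccc(CCc2ncc(CC3CCCC3)[nH]2)cc1`: 133 nM
compound 3, `O=C(O)c1ccccc1-c1ccc(CCc2ncc(Cc3ccc(F)cc3)[nH]2)cc1`: 1600 nM

Compound 1 stands second highest of the three numbers. The step of a 4.4-fold lower number from compound 1 to compound 2 (0.65 log units; beyond the scatter) leads to the lowest number of the set, and the step of a 2.7-fold higher number from compound 1 to compound 3 (0.43 log units; beyond the scatter) to the highest; between the two outer compounds the step is a 12-fold higher number from compound 2 to compound 3 (1.08 log units; beyond the scatter). Within these three, the larger saturated ring gives the lower number and the aromatic ring the higher.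

Compound 4, `O=C(O)c1ccccc1-c1ccc(CCc2ncc(-c3ccccc3)[nH]2)cc1`, is not yet measured. Against compound 1 the change is phenyl in place of cyclobutylmethyl on an aromatic carbon. The comparisons that bear on it are those in which an aromatic ring takes the place of a saturated ring, a 2.7-fold higher number from compound 1 to compound 3 (0.43 log units; beyond the scatter) and a 12-fold higher number from compound 2 to compound 3 (1.08 log units; beyond the scatter), both toward higher numbers and both beyond the scatter. Compound 4 differs from that case in that the phenyl sits directly on the aromatic carbon of the core and carries no fluorine, so the transfer is loose. A modest step to a higher number is expected, a 2.6-fold higher number from compound 1 to compound 4 (0.41 log units; beyond the scatter). Compound 4 is therefore estimated at 1500 nM, with a range from 500 nM to 5000 nM.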

Compound 4, half-maximal effective concentration: 4950 nM
The estimate for compound 4 lay 3.3-fold (0.52 log units) below the measured number; low and high end bracket the measured number.
By their numbers in this assay, from the lowest: compound 2; then compound 1; then compound 3; then compound 4.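

In this assay, phenyl on the aromatic carbon gives the highest number of the four compounds, and each comparison points the same way (an 8.4-fold higher number from compound 1 to compound 4 (0.93 log units; beyond the scatter)) (a 37-fold higher number from compound 2 to compound 4 (1.57 log units; beyond the scatter)) (a 3.1-fold higher number from compound 3 to compound 4 (0.49 log units; beyond the scatter)). The step from the 4-fluorobenzyl compound is the new finding: an aromatic ring is present on both sides of it, so the aromatic ring alone does not set the number, and the change from 4-fluorobenzyl to phenyl still moves it higher. In this set, all three groups with a saturated chain carbon between the ring and the core give lower numbers than phenyl, with no compound against that order, but nothing at hand explains the steps.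

The step from compound 3 to compound 4 combines loss of the chain carbon with loss of the fluorine, and an unsubstituted benzyl group would be needed to tell these two changes apart. Also open, from the compounds shown here alone, is whether a cyclopentyl ring set directly on the aromatic carbon would follow phenyl or cyclopentylmethyl, and whether cyclohexylmethyl or a longer chain would extend the trend from cyclobutylmethyl to cyclopentylmethyl.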